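A methyl-to-fluoro swap on compound 3

The source may report more compounds than this note shows. Statements on the series, on what has been measured and on what is new or still open speak of the compounds shown alone.

Compound 1 `CCCn1c(=O)[nH]c2nc(-c3ccc(S(=O)(=O)N4CCN(Cc5cccc(C)c5)CC4)cc3)[nH]c2c1=O` gives 0.397 nM in an assay on CHO cells for displacement of a labelled ligand from adenosine receptor A2b (Homo sapiens), read by scintillation counting, with a stated time of 75 min, in the presence of a further agent that is not named here; a lower number here means a stronger inhibitor, a higher number a weaker inhibitor. Compound 2 `CCCn1c(=O)[nH]c2nc(-c3ccc(S(=O)(=O)N(C)C)cc3)[nH]c2c1=O` gives 18.6 nM in this assay. Compound 3 `CCCn1c(=O)[nH]c2nc(-c3ccc(S(=O)(=O)N4CCN(c5ccccc5C)CC4)cc3)[nH]c2c1=O` gives 0.432 nM in this assay.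

Compound 3 stands second of the three numbers: compound 1 has a lower number, but a 1.1-fold higher number from compound 1 to compound 3 (0.04 log units; within the scatter), so the two are indistinguishable here, while compound 2 has a much higher number, beyond the scatter. Compound 4 `CCCn1c(=O)[nH]c2nc(-c3ccc(S(=O)(=O)N4CCN(c5ccccc5F)CC4)cc3)[nH]c2c1=O` differs from compound 3 in one place: fluoro in place of methyl on an aromatic carbon. For the measured compounds named here, only one measured step bears on this end of the molecule, the exchange of 3-methylbenzyl for 2-methylphenyl, and it was a 1.1-fold higher number from compound 1 to compound 3 (0.04 log units; within the scatter). Going by the values given here, no measured pair tests a fluoro in place of a methyl, so the step is read as a small one. On that basis compound 4 is expected to show a 1.2-fold higher number from compound 3 to compound 4 (0.06 log units; within the scatter), a change within the scatter, with no direction claimed. The estimate for compound 4 in this assay is therefore 0.5 nM, with a range from 0.2 nM to 1.3 nM.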

Compound 4, inhibition constant: 3.22 nM
The estimate for compound 4 lay 6.4-fold (0.81 log units) below the measured number; the whole stated range lies below it.
By their numbers in this assay, from the lowest: compounds 1 and 3 (each within the scatter of the next); then compound 4; then compound 2.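

Fluoro in place of methyl gave a 7.5-fold higher number from compound 3 to compound 4 (0.87 log units; beyond the scatter) in this assay, so this small group, on an aromatic carbon ortho to a large group, matters to the number, although the earlier step at this end of the molecule, a 1.1-fold higher number from compound 1 to compound 3 (0.04 log units; within the scatter), had shown no change beyond the scatter. The 2-fluorophenyl group also falls away from the 3-methylbenzyl group on the same ring nitrogen, with an 8.1-fold higher number from compound 1 to compound 4 (0.91 log units; beyond the scatter), which 2-methylphenyl did not do. Nothing available here accounts for the difference between methyl and fluoro at this position.

An unsubstituted phenyl, or a chloro or methoxy group at the same place, would show whether the methyl is favoured or the fluoro penalised. From the compounds shown here alone, whether the same swap has a similar effect on the 3-methylbenzyl group remains open.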